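This account rests on a few compounds, and the source may have more. Where it says the series, first, only, none or still open, it means among the compounds named here.

Three compounds share one core, differing only in the aryl group on the fused ring. Compound 1 `O=S(=O)(c1cc(Cl)cc(Cl)c1)c1cnc2c(F)cccc2c1-c1cccc(Cl)c1` gives 1.2 mL/min in an ADME assay on microsomes from liver (Homo sapiens) for metabolic stability, tested at 2.5 uM; on this read-out lower numbers stand for slow clearance and higher numbers for fast clearance. Compound 2 `O=S(=O)(c1cc(Cl)cc(Cl)c1)c1cnc2c(F)cccc2c1-c1ccc(F)cc1` gives 1.01 mL/min. Compound 3 `COc1ccc(-c2c(S(=O)(=O)c3cc(Cl)cc(Cl)c3)cnc3c(F)cccc23)cc1` gives 2.11 mL/min. On these numbers compound 3 stands apart only on one step, a 2.1-fold higher number from compound 2 to compound 3 (0.32 log units; beyond the scatter), whereas a 1.8-fold higher number from compound 1 to compound 3 (0.25 log units; within the scatter) and a 1.2-fold lower number from compound 1 to compound 2 (0.07 log units; within the scatter).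

Compound 4 `O=S(=O)(c1cc(Cl)cc(Cl)c1)c1cnc2c(F)cccc2c1-c1ccccc1F` differs from compound 3 as follows: 2-fluorophenyl in place of 4-methoxyphenyl on an aromatic carbon. Among the measured compounds shown here, the steps that bear on this are the two arriving at compound 3 from a halophenyl group, a 1.8-fold higher number from compound 1 to compound 3 (0.25 log units; within the scatter) and a 2.1-fold higher number from compound 2 to compound 3 (0.32 log units; beyond the scatter), both pointing the same way, while the two halophenyl compounds agree with each other. Since compound 4 again carries a halophenyl group, the expected move is back toward those two numbers. For the measured compounds named here, no measured pair places fluorine at the position it takes in compound 4, so the range is kept wide. For compound 4 a modest downward step is expected, a 1.9-fold lower number from compound 3 to compound 4 (0.28 log units; within the scatter). Compound 4 is estimated at 1.1 mL/min, with a range from 0.6 mL/min to 2.2 mL/min.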

Compound 4, intrinsic clearance in a liver preparation (reported as CLH), per the amount of preparation that the assay uses: 0.44 mL/min
Compound 4: the middle estimate sits 2.5-fold (0.40 log units) above what was measured; measured number below the stated range.
By their numbers in this assay, from the lowest: compound 4; then compounds 2, 1 and 3 (each within the scatter of the next, the first and the last beyond it).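

In this assay this position proves more responsive than the earlier halophenyl compounds suggested: the switch to 2-fluorophenyl gives a 4.8-fold lower number from compound 3 to compound 4 (0.68 log units; beyond the scatter) and also separates from both earlier halophenyl groups, with a 2.3-fold lower number from compound 2 to compound 4 (0.36 log units; beyond the scatter) and a 2.7-fold lower number from compound 1 to compound 4 (0.44 log units; beyond the scatter) on the same downward side. A halophenyl group alone therefore does not set the number, as the change from 4-fluorophenyl to 2-fluorophenyl keeps the same atoms and still moves beyond the scatter. Nothing available explains this shift.

Among the compounds shown here, with compound 4 the only 2-substituted phenyl group here, it stays open whether the lower number is particular to fluorine or would hold for 2-chlorophenyl or 2-methoxyphenyl. As far as these compounds go, how an amine or a carboxylic acid on this phenyl group would read also remains open.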